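Swapping the furan for a fluoro-methoxyphenyl on the amine chain

This account rests on a few compounds, and the source may have more. Where it says the series, first, only, none or still open, it means among the compounds named here.

Of the compounds shown here, three have so far been measured in an ADME assay for permeability, using PAMPA, with a stated time of 30 min, at pH 7.4; a higher number here means that the compound crosses the layer faster, a lower number that the compound crosses the layer more slowly. Among the measured compounds shown here, compound 1 `COc1ccc(F)cc1CNCCCNc1ccnc2cc(Cc3cc(C)cc(C)c3)ccc12` gives 23 10^-6 cm/s, and compound 2 `COc1ccc(F)cc1CNCCCNc1ccnc2cc(Cc3ccc(C#N)cc3)ccc12` gives 23 10^-6 cm/s; the one measured step, no change at the digits printed from compound 1 to compound 2 (within the scatter), therefore sits within the scatter. Compound 3 `CN(C)c1cccc(Oc2ccc3c(NCCCNCc4ccco4)ccnc3c2)c1` stands highest of the three in this assay with 317 10^-6 cm/s, and its nearest and furthest neighbours, compound 1 and compound 2, both lie well beyond the scatter below it.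

Compound 4 `COc1ccc(F)cc1CNCCCNc1ccnc2cc(Oc3cccc(N(C)C)c3)ccc12` is the next to be measured, and it differs from compound 3 in one place: 5-fluoro-2-methoxyphenyl in place of furan-2-yl on a saturated chain carbon bound to an amine nitrogen. For the measured compounds named here, the only measured step, from compound 1 to compound 2, concerns a different place in the molecule and so does not bear on this change. Compound 1 and compound 2 carry the same 5-fluoro-2-methoxybenzyl group that enters here, yet they also differ from compound 3 elsewhere, so their lower numbers cannot be assigned to this group alone. On that basis compound 4 is expected to fall between compound 3 and the other two, an estimated step of a 2.6-fold lower number from compound 3 to compound 4 (0.42 log units; beyond the scatter) downward. Compound 4 is estimated at 120 10^-6 cm/s, with a range from 40 10^-6 cm/s to 350 10^-6 cm/s.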

Compound 4, apparent permeability in the ADME assay: 317 10^-6 cm/s
Compound 4: the middle estimate sits 2.6-fold (0.42 log units) below what was measured, and the stated range covers the measured number.
By their numbers in the ADME assay, from the lowest: compounds 1 and 2 (each within the scatter of the next); then compounds 3 and 4 (each within the scatter of the next).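

In the ADME assay, the change on the saturated chain carbon bound to an amine nitrogen gives no change at the digits printed from compound 3 to compound 4 (within the scatter), so 5-fluoro-2-methoxyphenyl does not by itself go with a low number, and the large steps lie at the aromatic carbon instead: a 14-fold higher number from compound 2 to compound 4 (1.14 log units; beyond the scatter) with 3-(dimethylamino)phenoxy in place of 4-cyanobenzyl, and a 14-fold higher number from compound 1 to compound 4 (1.14 log units; beyond the scatter) with it in place of 3,5-dimethylbenzyl. In a physicochemical assay for acid dissociation, compound 3 gives 9.28 and compound 4 gives 9.28, which is no change at the digits printed from compound 3 to compound 4 (within the scatter). Nothing measured here explains either the absence of change or the large steps.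

As far as these compounds go, whether a carboxylic acid or a longer chain on the amine nitrogen would leave these numbers equally unchanged remains open. The compounds shown also do not separate the oxygen link of 3-(dimethylamino)phenoxy from its dimethylamino group.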